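The source may report more compounds than this note shows. Statements on the series, on what has been measured and on what is new or still open speak of the compounds shown alone.

Values so far in a functional assay on HT-29 cells (Homo sapiens) for cytotoxicity, read by MTT assay, with a stated time of 48 h (on this read-out lower numbers stand for stronger inhibition and higher numbers for weaker inhibition), for each compound:
compound 1 (`COc1cc(/C=C/C(=O)/C=C(/C=C/c2ccc(O)c(OC)c2)NCCO)ccc1O`) gives > 100000 nM
compound 2 (`O=C(/C=C(/C=C/c1ccc(O)cc1)NCCCO)/C=C/c1ccc(O)cc1`) gives 58900 nM
compound 3 (`COc1cc(/C=C/C(=O)/C=C(/C=C/c2ccc(O)c(OC)c2)NCCCO)ccc1O`) gives > 100000 nM

The entry of > 100000 nM for compound 1 is a limit of the assay and not a number. The entry of > 100000 nM for compound 3 is likewise a limit and not a number. Among the compounds with values here, that leaves compound 2 at 58900 nM as the only true number in this assay so there is no other measured potency to rank it against.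

Compound 4 (`COCCCNC(=C\C(=O)/C=C/c1ccc(O)cc1)/C=C/c1ccc(O)cc1`) is compound 2 with one change, methyl in place of hydrogen on an oxygen on a saturated carbon, which turns hydroxy into methoxy (methyl in place of hydrogen on an oxygen on a saturated carbon). Within the data shown here, the one measured step at this hydroxy group is a step that the two limits leave unreadable from compound 1 to compound 3 and it offers no size to carry over. With nothing measured to suggest a real shift, the expected result is a 1.2-fold higher number from compound 2 to compound 4 (0.07 log units; within the scatter) and so no change beyond the usual scatter. Compound 2 at 58900 nM already lies fairly close to the top of the readable range. Compound 4 may therefore also be expected to return only (the limit of > 100000 nM in this assay, at which 2 of the 3 values shown sit). For compound 4 the estimate is 70000 nM with an expected range of 30000 nM to 150000 nM in this assay if a number is obtained.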

Compound 4, half-maximal inhibitory concentration: 51900 nM
For compound 4 the middle estimate is 1.3-fold (0.13 log units) above the measured one, within the range that was stated.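

In this assay, within the data shown here, methyl in place of hydrogen on the chain-end oxygen gives a 1.1-fold lower number from compound 2 to compound 4 (0.05 log units; within the scatter), the first step at this end of the chain with a size that can be read. Among these compounds, the earlier step here, from hydroxy to hydroxymethyl, joins two limits of the assay and cannot be read, so this pair is the only direct look at what this position tolerates. In this one pair, turning hydroxy into methoxy removes the hydrogen on that oxygen without a change beyond the usual scatter, so a free hydroxy is not needed to keep the number where it stands on this core.

From the compounds shown here alone, whether a different group at the chain end, such as an amine, a carboxylic acid or a longer chain ending in methoxy, would move the number beyond the scatter remains open, as does the effect of the same methyl on the core of compound 3. The room for reading any such change is also narrow in this set of compounds: the limit of > 100000 nM in this assay, at which 2 of the 4 values shown sit.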